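The compounds below may be only part of what the source reports. "The series", "measured", "known", "first", "only" and "open" are said of these compounds alone.

Working notes on the sulfur substituent. In a functional assay on HT cells (Homo sapiens) for antiproliferative activity, read by fluorescence, with a stated time of 72 h (on this read-out higher numbers stand for weaker inhibition of growth and lower numbers for stronger inhibition of growth), compound 3 `CC(C)c1n[nH]c2c(NCc3ccc(-c4ccccn4)cc3)nc(SC3CCCC3O)nc12` gives 567 nM, level within the scatter with compound 2 `CC(C)c1n[nH]c2c(NCc3ccc(-c4ccccn4)cc3)nc(SC3CCCCC3O)nc12` at 636 nM, while compound 1 `CC(C)c1n[nH]c2c(NCc3ccc(-c4ccccn4)cc3)nc(SCCN)nc12` gives 22 nM. Compound 4 `CC(C)c1n[nH]c2c(NCc3ccc(-c4ccccn4)cc3)nc(S)nc12` has hydrogen in place of 2-hydroxycyclopentyl on a sulfur. Among the measured compounds shown here, no measured step removes the substituent outright, so the evidence is indirect. The ring change gives only a 1.1-fold lower number from compound 2 to compound 3 (0.05 log units; within the scatter), whereas the large steps of a 29-fold higher number from compound 1 to compound 2 (1.46 log units; beyond the scatter) and a 26-fold higher number from compound 1 to compound 3 (1.41 log units; beyond the scatter) both start from the 2-aminoethyl compound 1. Neither hydroxy compound therefore predicts a large shift, and only a small move towards a higher number is expected, with wide uncertainty. The estimated step is a 1.4-fold higher number from compound 3 to compound 4 (0.15 log units; within the scatter). For compound 4 the expected value is 800 nM, with an estimated range of 180 nM to 3500 nM.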

Compound 4, concentration for 50% growth inhibition: 2760 nM
The estimate for compound 4 lay 3.5-fold (0.54 log units) below the measured number, and the stated range covers the measured number.
By their numbers in this assay, from the lowest: compound 1; then compounds 3 and 2 (each within the scatter of the next); then compound 4.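

Bare sulfanyl is the poorest of the four, so the hydroxy rings are not neutral at this sulfur: replacing either with hydrogen still weakens growth inhibition (2-hydroxycyclopentyl: a 4.9-fold higher number from compound 3 to compound 4 (0.69 log units; beyond the scatter); 2-hydroxycyclohexyl: a 4.3-fold higher number from compound 2 to compound 4 (0.64 log units; beyond the scatter)). The larger gain belongs to 2-aminoethyl, and the position now has a full measured span (a 130-fold higher number from compound 1 to compound 4 (2.10 log units; beyond the scatter)).

Whether that gain comes from the amine or the open chain stays unresolved; a 2-hydroxyethyl group or a longer amine chain on the sulfur would separate the two. Nothing measured here explains these steps.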